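The source may hold more compounds than are shown below. What is called first, only, known or untested is meant among the compounds shown, and "the series" means these compounds.

Measured so far in a functional assay on A549 cells (Homo sapiens) for cytotoxicity, read by MTT assay, with a stated time of 48 h; a lower number here means a stronger inhibitor, a higher number a weaker inhibitor:

Compound 1 `COc1ccc(OC)c(C2=NOC(COc3ccc(-c4nnnn4-c4cc(OC)c(OC)c(OC)c4)cc3N)C2)c1` gives 1930 nM
Compound 2 `COc1ccc(C2=NOC(COc3ccc(-c4nnnn4-c4cc(OC)c(OC)c(OC)c4)cc3N)C2)cc1O` gives 2130 nM
Compound 3 `COc1cc(C2=NOC(COc3ccc(-c4nnnn4-c4cc(OC)c(OC)c(OC)c4)cc3N)C2)ccc1O` gives 2010 nM

Compound 3 cannot be separated from the other two compounds on these numbers. The steps of a 1.0-fold higher number from compound 1 to compound 3 (0.02 log units; within the scatter) and a 1.1-fold lower number from compound 2 to compound 3 (0.03 log units; within the scatter) both stay within the scatter, and so does a 1.1-fold higher number from compound 1 to compound 2 (0.04 log units; within the scatter) among the remaining pair.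

The unmeasured compound 4 `COc1ccc(C2=NOC(COc3ccc(-c4nnnn4-c4cc(OC)c(OC)c(OC)c4)cc3N)C2)cc1[N+](=O)[O-]` differs from compound 3 in a single place: 4-methoxy-3-nitrophenyl in place of 4-hydroxy-3-methoxyphenyl on a carbon with a double bond to nitrogen and the rest of the molecule is shared.

Only the measured exchanges at this same place bear on the change. Among the compounds with values here, the one measured group without a hydroxy, 2,5-dimethoxyphenyl, gives the step of a 1.0-fold higher number from compound 1 to compound 3 (0.02 log units; within the scatter) and so offers the closest comparison for a group lacking it. Within the data shown here, no measured compound carries a nitro group, however, so the entering group itself is untested and the range must stay wide.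

On this evidence, no shift beyond the scatter is expected in this assay for this change. The expected step is a 1.1-fold higher number from compound 3 to compound 4 (0.04 log units; within the scatter) with no firm direction. For compound 4 the estimated value is 2200 nM with an expected range from 800 nM to 6000 nM in this reading.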

Compound 4, half-maximal inhibitory concentration: 2220 nM
Compound 4: middle estimate off by 1.0-fold (0.00 log units), on the low side, and the stated range covers the measured number.
By their numbers in this assay, from the lowest: compounds 1, 3, 2 and 4 (each within the scatter of the next).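

In this assay, a nitro group now enters the aryl group on the carbon with a double bond to nitrogen, and the number stays level with the others: 4-methoxy-3-nitrophenyl in place of 4-hydroxy-3-methoxyphenyl is a 1.1-fold higher number from compound 3 to compound 4 (0.04 log units; within the scatter), nitro in place of hydroxy on an aromatic carbon is a 1.0-fold higher number from compound 2 to compound 4 (0.02 log units; within the scatter), and 4-methoxy-3-nitrophenyl in place of 2,5-dimethoxyphenyl is a 1.2-fold higher number from compound 1 to compound 4 (0.06 log units; within the scatter). The earlier compounds shown here had covered only hydroxy and methoxy groups on this aryl ring, whereas these steps show that a nitro group, with no hydrogen-bond donor in the entering group, also leaves the number within the scatter of all three others. Nothing available here explains why these exchanges at this place make so little difference.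

As far as these compounds go, whether an amine or a carboxylic acid on this aryl ring, or a longer alkyl chain in place of the ring, would move the number beyond the scatter remains open. Also open, from the compounds shown here alone, is how much the rest of the molecule, shared by all four compounds, contributes to the values in this assay.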